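Adding a Bromine to the Phenyl Ring

A few compounds are considered here, and "the series" means these few. Any claim that something is new, unique, unknown or untested is made for them only; others in the source may bear on it.

Going by the values given here, compound 1 `COc1cc(/C=N/Nc2nc(-c3ccccc3)cs2)c(Br)c(Br)c1OC` was tested in a functional assay on A549 cells (Homo sapiens) for inhibition, read by MTT assay, with a stated time of 48 h (on this read-out higher numbers stand for weaker inhibition and lower numbers for stronger inhibition), and in this assay compound 1 gives 15300 nM, the only plain number measured so far. Compound 2 `COc1cc(/C=N/Nc2nc(-c3cc(C(F)(F)F)cc(C(F)(F)F)c3)cs2)c(Br)c(Br)c1OC` reaches only a limit of the assay, > 100000 nM. Compound 3 `COc1cc(/C=N/Nc2nc(-c3ccc(Br)cc3)cs2)c(Br)c(Br)c1OC` differs from compound 1 by bromo in place of hydrogen on an aromatic carbon. Among the compounds with values here, no measured step of this kind is available, so the change is expected to shift the reading by a 1.3-fold higher number from compound 1 to compound 3 (0.12 log units; within the scatter), a step that would stay within the usual scatter. Compound 3 is estimated at 20000 nM, with a range from 6000 nM to 70000 nM.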

Compound 3, half-maximal inhibitory concentration: 46100 nM
For compound 3 the middle estimate is 2.3-fold (0.36 log units) below the measured one; measured number inside the range.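

In this assay, going by these compounds alone, the change from phenyl to 4-bromophenyl gives a 3.0-fold higher number from compound 1 to compound 3 (0.48 log units; beyond the scatter), the first measured step at this position. A single added bromine on this ring is therefore enough to weaken inhibition modestly, so this position does respond to a change. Nothing shown here explains the size of this step. Going by these compounds, whether this weakening is particular to bromo remains open. An amine, a carboxylic acid or a methoxy group at the same place could move the reading either way.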